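Removing a methyl: from compound 2 to compound 3

A few compounds are considered here, and "the series" means these few. Any claim that something is new, unique, unknown or untested is made for them only; others in the source may bear on it.

compound 1 `Cc1nc(Nc2ccccc2)sc1C(=O)/C=C/c1ccc(Cl)cc1`: > 25000 nM
compound 2 `Cc1cccc(Nc2nc(C)c(C(=O)/C=C/c3ccccc3)s2)c1`: 13600 nM

In a functional assay on BGC-823 cells (Homo sapiens) for cytotoxicity, read by MTT assay (a lower number here means a stronger inhibitor, a higher number a weaker inhibitor), compound 1 gives > 25000 nM, which is a limit of the assay and not a number, as noted in the limit of > 25000 nM in this assay, at which 1 of the 2 values shown sits. In this assay compound 2 gives 13600 nM, the only actual number shown, so it stands alone. Compound 3 `Cc1nc(Nc2ccccc2)sc1C(=O)/C=C/c1ccccc1` differs from compound 2 by hydrogen in place of methyl on an aromatic carbon. Among the compounds with values here, no measured step covers such a change. A small step is expected, a 1.5-fold higher number from compound 2 to compound 3 (0.17 log units; within the scatter), likely none beyond the scatter or a slight weakening. Compound 3 is estimated at 20000 nM, between 8000 nM and 60000 nM.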

Compound 3, half-maximal inhibitory concentration: 19500 nM
For compound 3 the middle estimate is 1.0-fold (0.01 log units) above the measured one; the measured number falls inside the stated range.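

In this assay, the change from 3-methylphenyl to phenyl gives a 1.4-fold higher number from compound 2 to compound 3 (0.16 log units; within the scatter), so removing this methyl has no effect beyond the scatter. Hydrogen in place of chloro on an aromatic carbon gives an at least 1.2-fold lower number from compound 1 to compound 3 (0.10 log units; that floor lies within the scatter), and this floor shows no clear effect of the chloro group either. That step starts from compound 1, whose value is a limit of the assay and not a number: the limit of > 25000 nM in this assay, at which 1 of the 3 values shown sits.

From the compounds shown here alone, it remains open whether an amine or a carboxylic acid at either of these places would shift the number beyond the scatter.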